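Flipping the Stilbene Double Bond from Z to E

The source may hold more compounds than are shown below. What is called first, only, known or untested is meant among the compounds shown, and "the series" means these compounds.

Compound 3 `Cc1cc(C)cc(/C=C\c2ccc(N3CCNC3=O)cc2)c1` holds the only numeric result in a functional assay on HT-29 cells (Homo sapiens) for inhibition, read by sulforhodamine B assay, with a stated time of 48 h (a higher number here means a weaker inhibitor, a lower number a stronger inhibitor), where compound 3 gives 8.4 nM. The two other results are limits rather than numbers. In this assay compound 1 `CCNC(=O)Nc1ccc(/C=C/c2cccc(Cl)c2)cc1` gives the limit > 20000 nM. Likewise compound 2 `CCNC(=O)Nc1ccc(/C=C/c2cc(C)cc(C)c2)cc1` gives the limit > 20000 nM. Both sit at the limit of > 20000 nM in this assay, at which 2 of the 3 values shown sit, and both carry a double bond drawn E, though with a different side group. Compound 4 `Cc1cc(C)cc(/C=C/c2ccc(N3CCNC3=O)cc2)c1` is not yet measured; it differs from compound 3 by the two compounds have the same atoms and bonds and differ only in configuration as drawn: 1 of 1 stereo elements differ; a double bond is drawn Z in compound 3 and E in compound 4. Going by the values given here, no measured pair here isolates this change. Still, a large loss is expected, and compound 4 is estimated at 4000 nM (range 300 nM to 20000 nM), a step of a 480-fold higher number from compound 3 to compound 4 (2.68 log units; beyond the scatter) expected to go well beyond the scatter.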

Compound 4, half-maximal inhibitory concentration: 14000 nM
Beside the measured number, compound 4's estimate is 3.5-fold (0.54 log units) below it; the range from low to high includes it.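

In this assay, the double bond now has a measured effect of its own, a 1700-fold higher number from compound 3 to compound 4 (3.22 log units; beyond the scatter), and this loss can be tied to that single feature: the fact that compounds 3 and 4 differ only in the configuration as drawn. With the double bond drawn E in both compounds, changing the side group gives an at least 1.4-fold lower number from compound 2 to compound 4 (0.15 log units; that floor lies within the scatter), so nothing here suggests that 2-oxoimidazolidin-1-yl makes up for the E form.

Still open, going by these compounds, is whether (ethylcarbamoyl)amino would do as well on a Z double bond. Also open, on these data alone, is whether an amine or a carboxylic acid could replace 2-oxoimidazolidin-1-yl on the Z form and keep a low number.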